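The source may report more compounds than this note shows. Statements on the series, on what has been measured and on what is new or still open speak of the compounds shown alone.

Measured so far in a functional assay on RAW264.7 cells (Mus musculus) for inhibition, read by Griess assay, with a stated time of 20 h; a lower number here means a stronger inhibitor, a higher number a weaker inhibitor:
- Compound 1 `CCCCCCc1cn(-c2ccc(O)c(C(=O)N3CCCCC3)c2)nn1`: > 20000 nM, a limit
- Compound 2 `CCCNC(=O)c1ccc(-n2cc(-c3ccccc3)nn2)cc1O`: > 20000 nM, a limit

For the measured compounds named here, the series so far is summed up by the limit of > 20000 nM in this assay, at which 2 of the 2 values shown sit. Neither compound has a measured number, so no order can be drawn between them. Compound 2 therefore stands only at a limit, > 20000 nM, and offers no exact starting value.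

The next compound is compound 3 `CCCNC(=O)c1ccc(-n2cc(CCC(C)C)nn2)cc1O`. It differs from compound 2 by one change: isopentyl in place of phenyl on an aromatic carbon of the five-membered aromatic ring with 3 nitrogen (isopentyl in place of phenyl on an aromatic carbon).

Going by the values given here, no step between measured compounds is available to size this change in this assay. Compound 1 is also a limit, > 20000 nM, so it gives no sign of a favoured direction either. The expectation is therefore no change beyond the scatter, and another limit would be no surprise. The expected step of a number no higher from compound 2 to compound 3 (the limit leaves the size open) is an estimate with no direction favoured. Compound 3 is expected near 20000 nM, with an estimated range of 8000 nM to 40000 nM.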

Compound 3, half-maximal inhibitory concentration: > 20000 nM
Compound 3 gave a limit, no number; the forecaster's own chance of this, stated with the estimate: 65%; the middle value sits exactly at the limit.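

Compound 2 and compound 3 both stand at a limit, not a number, so no step can be read for isopentyl in place of phenyl in this assay. The compounds shown leave open whether any change to these structures would give a measured number rather than a limit: the limit of > 20000 nM in this assay, at which 3 of the 3 values shown sit.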